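Piperazine in Place of Cyclohexyl on an Acid Ceramidase Inhibitor

A few compounds are considered here, and "the series" means these few. Any claim that something is new, unique, unknown or untested is made for them only; others in the source may bear on it.

Measured compounds:
Compound 1, `O=C(NCCCCc1ccccc1)n1c(=O)oc2cc(C3CCCCC3)ccc21`: 89 nM
Compound 2, `CC(C)CNC(=O)n1c(=O)oc2cc(C3CCCN(C)C3)ccc21`: 1750 nM
Compound 3, `COCCCNC(=O)n1c(=O)oc2cc(-c3ccc(F)cc3)ccc21`: 2600 nM

In an assay on HEK293 cells for inhibition of acid ceramidase (Homo sapiens), read by fluorescence, with stated times of 10 min and 3 h (on this read-out lower numbers stand for stronger inhibition and higher numbers for weaker inhibition), compound 1 gives the lowest of the three numbers. Compound 2 and compound 3 both give higher numbers, and each of those gaps lies beyond the scatter of the measurement, so compound 1 is the strongest inhibitor among the compounds measured. Neither compound 2 nor compound 3 differs from compound 1 in a single place, so their numbers show only where they stand, not the effect of any one change.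

Compound 4, `CC(C)CN1CCN(c2ccc3c(c2)oc(=O)n3C(=O)NCCCCc2ccccc2)CC1`, has not yet been measured. It differs from compound 1 in one place: 4-isobutylpiperazin-1-yl in place of cyclohexyl on an aromatic carbon. The rest of the molecule, including the chain on the carbamoyl group, is kept. Within the data shown here, with no single-point step recorded in this assay, the size of the change has to be guessed. Compound 2, which carries a nitrogen-containing ring at a related position, gives 1750 nM, a weaker result. Compound 4 is therefore estimated to give 350 nM, in a range from 80 nM to 1500 nM. The estimated step of a 3.9-fold higher number from compound 1 to compound 4 (0.59 log units; beyond the scatter) is expected to be a moderate weakening, beyond the scatter.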

Compound 4, half-maximal inhibitory concentration: 127 nM
Beside the measured number, compound 4's estimate is 2.8-fold (0.44 log units) above it; the range from low to high includes it.
By their numbers in this assay, from the lowest: compounds 1 and 4 (each within the scatter of the next); then compounds 2 and 3 (each within the scatter of the next).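

In this assay, the step for 4-isobutylpiperazin-1-yl in place of cyclohexyl reads a 1.4-fold higher number from compound 1 to compound 4 (0.15 log units; within the scatter), so on this aromatic carbon the larger group, with its two ring nitrogens, is accepted with the 4-phenylbutyl-bearing rest of compound 1 kept. The earlier compounds shown here could not show this, since compound 2 and compound 3 each differ from compound 1 in more than one place and their higher numbers cannot be assigned to the group at this position. Nothing measured here accounts for the two groups reading alike.

The compounds shown leave open whether this holds when the isobutyl on the piperazine is replaced by a hydrogen, a methyl or a carboxylic acid-bearing chain. They also leave open whether a morpholine at this position would read the same way.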